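Thiourea aryl variation on the shared core

The compounds below may be only part of what the source reports. "The series", "measured", "known", "first", "only" and "open" are said of these compounds alone.

Compound 1 `CNC(=O)c1ccc(Sc2ccc(NC(=S)Nc3cc(C(F)(F)F)cc(C(F)(F)F)c3)cc2)nc1` carries a 3,5-bis(trifluoromethyl)phenyl on the thiourea and in a functional assay on B16-BL6 cells (Mus musculus) for cytotoxicity, read by MTT assay, with a stated time of 48 h (on this read-out lower numbers stand for stronger inhibition and higher numbers for weaker inhibition), compound 1 gives 36100 nM. Compound 2 `CNC(=O)c1ccc(Sc2ccc(NC(=S)Nc3cccc(C(F)(F)F)c3)cc2)nc1` in this assay gives 53100 nM. The step of a 1.5-fold higher number from compound 1 to compound 2 (0.17 log units; within the scatter) is small. Compound 3 `CNC(=O)c1ccc(Sc2ccc(NC(=S)Nc3ccc(OC(F)(F)F)cc3)cc2)nc1` in this assay gives only a limit of > 100000 nM. Among the two numbers shown, compound 2 has the higher one, with compound 1 as its nearest neighbour within the scatter.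

Compound 4 `CNC(=O)c1ccc(Sc2ccc(NC(=S)Nc3ccc(F)c(F)c3)cc2)nc1` is the next variation: 3,4-difluorophenyl in place of 3-(trifluoromethyl)phenyl on an amide-type nitrogen. No measured step covers this exchange directly; the one step shown, a 1.5-fold higher number from compound 1 to compound 2 (0.17 log units; within the scatter), says that removing one trifluoromethyl from the aryl changed little, while the limit of > 100000 nM in this assay, at which 1 of the 3 values shown sits, shows a compound with a different aryl reaching only the upper limit. A step of modest size in the direction of a higher number, or none beyond the scatter, is therefore expected in this assay. For compound 4 the expected value is 70000 nM, with a range from 30000 nM to 150000 nM. That estimate corresponds to an expected step of a 1.3-fold higher number from compound 2 to compound 4 (0.12 log units; within the scatter).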

Compound 4, half-maximal inhibitory concentration: 52600 nM
Beside the measured number, compound 4's estimate is 1.3-fold (0.12 log units) above it, within the range that was stated.
By their numbers in this assay, from the lowest: compounds 1, 4 and 2 (each within the scatter of the next). At a limit, above all of these: compound 3.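

The exchange of 3-(trifluoromethyl)phenyl for 3,4-difluorophenyl on an amide-type nitrogen gives a 1.0-fold lower number from compound 2 to compound 4 (0.00 log units; within the scatter) in this assay. A trifluoromethyl group on this aryl is therefore not required for a value of this size, since compound 4, with fluorine as its only aryl substituent, stands within the scatter of compound 2. Within the data shown here, the aryl is not freely exchangeable, however, as compound 3, with its 4-(trifluoromethoxy)phenyl, remains the one compound read only as a limit rather than a number: the limit of > 100000 nM in this assay, at which 1 of the 4 values shown sits.

Open, as far as these compounds go, is how an aryl carrying an amine or a carboxylic acid would read in this assay. Also open, from the compounds shown here alone, is whether a urea in place of the thiourea on the shared core would stay within the same range.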